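A few compounds are considered here, and "the series" means these few. Any claim that something is new, unique, unknown or untested is made for them only; others in the source may bear on it.

Three analogues sharing one core have been measured in a functional assay on MGC-803 cells (Homo sapiens) for inhibition, read by MTT assay, with a stated time of 72 h; a higher number here means a weaker inhibitor, a lower number a stronger inhibitor. Compound 1 `O=C(CSc1nc(Nc2ccccc2)c2ccccc2n1)Nc1ccccc1F` gives 10700 nM in this assay. Compound 2 `O=C(CSc1nc(Nc2ccccc2)c2ccccc2n1)Nc1cccc(F)c1` gives 12700 nM, and the step of a 1.2-fold higher number from compound 1 to compound 2 (0.07 log units; within the scatter) does not leave the scatter. Compound 3 `O=C(CSc1nc(Nc2ccccc2)c2ccccc2n1)Nc1cccc([N+](=O)[O-])c1` gives 28100 nM, the highest number of the three; the steps of a 2.6-fold higher number from compound 1 to compound 3 (0.42 log units; beyond the scatter) and a 2.2-fold higher number from compound 2 to compound 3 (0.34 log units; beyond the scatter) both exceed the scatter, so compound 3 is the weakest inhibitor of the measured set.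

Compound 4 `CCc1cccc(NC(=O)CSc2nc(Nc3ccccc3)c3ccccc3n2)c1` has not yet been run. The change from compound 3 reads (ethyl in place of nitro on an aromatic carbon). For the measured compounds named here, only one measured step touches the same aromatic carbon: a 2.2-fold higher number from compound 2 to compound 3 (0.34 log units; beyond the scatter), where installing the nitro raised the number modestly. Going by the values given here, no measured pair exchanges nitro for ethyl, so the direction of the new step rests on that single comparison. Since the nitro-bearing compound 3 gave the highest number, with 28100 nM, removing the nitro is expected to give a modest move downward rather than upward, of about a 1.9-fold lower number from compound 3 to compound 4 (0.27 log units; within the scatter) in this assay, with a real chance that the step stays within the scatter. Compound 4 is therefore estimated at 15000 nM in this assay, with a range from 6000 nM to 38000 nM.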

Compound 4, half-maximal inhibitory concentration: 15800 nM
Beside the measured number, compound 4's estimate is 1.1-fold (0.02 log units) below it; measured number inside the range.
By their numbers in this assay, from the lowest: compounds 1, 2, 4 and 3 (each within the scatter of the next, the first and the last beyond it).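

In this assay, for the compounds shown here, ethyl and nitro cannot be told apart at this aromatic carbon: a 1.8-fold lower number from compound 3 to compound 4 (0.25 log units; within the scatter), so the one pair that exchanges them shows no separation, although ethyl carries no hydrogen-bond acceptors and nitro does. Ethyl also cannot be told apart from fluoro at the same carbon, with a 1.2-fold higher number from compound 2 to compound 4 (0.09 log units; within the scatter), and the exchange of 2-fluorophenyl for 3-ethylphenyl gives a 1.5-fold higher number from compound 1 to compound 4 (0.17 log units; within the scatter), so compound 4 lies within the scatter of all three earlier compounds and compound 3 keeps its separation only from compound 1 and compound 2. Nothing available alongside these numbers bears on why the steps fall as they do.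

On these data alone, whether any group at this aromatic carbon moves the number well clear of the scatter remains open, for instance an amine, a carboxylic acid or a longer chain such as hexyl. The compounds shown also share the rest of the core of compound 1, so they leave open what a change elsewhere in that core, such as on the unsubstituted phenyl, would do in this assay.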